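Sulfoxide-bearing phenyl replaces fluoropyridine at the ring nitrogen

The source may report more compounds than this note shows. Statements on the series, on what has been measured and on what is new or still open speak of the compounds shown alone.

Three compounds share one core and differ only in the aromatic group attached to it. Compound 1 `CC(C)OC(=O)N1CCC(Oc2ncnc3c2CCN3c2ccc(-c3cccn3C)cc2F)CC1` carries a fluorophenyl bearing a methylpyrrolyl group, and in a functional assay on CHO-K1 cells for agonist activity at Glucose-dependent insulinotropic receptor (Homo sapiens), read by a luciferase reporter, with a stated time of 5 h (a lower number here means that less compound is needed, a higher number that more compound is needed for the effect), compound 1 gives 158 nM. Compound 2 `CC(C)OC(=O)N1CCC(Oc2ncnc3c2CCN3c2ccc(F)cn2)CC1` carries a 5-fluoropyridin-2-yl group instead. For compound 2 this assay reports only a limit, > 10000 nM, so no number is known; this is the limit noted as the limit of > 10000 nM in this assay, at which 1 of the 2 values shown sits. Compound 3 `CC(C)OC(=O)N1CCC(Oc2ncnc3c2CCN3c2ccc([S@+](C)[O-])c(F)c2)CC1` is the compound still to be measured. Relative to compound 2 it carries a group of 10 heavy atoms (7 carbon, 1 oxygen, 1 fluorine, 1 sulfur; one six-membered aromatic ring of carbon only) in place of a group of 7 heavy atoms (5 carbon, 1 nitrogen, 1 fluorine; one six-membered aromatic ring with 1 hetero atom), on a nitrogen on an aromatic ring in a ring. No measured pair differs in one place, so the size of this step is not known from the shown data. Compound 3 is expected to fall at about 700 nM, within 120 nM to 6000 nM, because compound 1 gives 158 nM with a substituted carbon-only ring in the same place. This means an expected step from the limit of an at least 14-fold lower number from compound 2 to compound 3 (1.15 log units; beyond the scatter).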

Compound 3, half-maximal effective concentration: 50.1 nM
Compound 3: middle estimate off by 14-fold (1.15 log units), on the high side, outside the stated range (below it).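

In this assay, exchanging the 5-fluoropyridin-2-yl group for the sulfoxide-bearing fluorophenyl group on the ring nitrogen gives an at least 190-fold lower number from compound 2 to compound 3 (2.30 log units; beyond the scatter). With the rest of the molecule unchanged, this shows that the group at this nitrogen alone can decide whether the shared core gives a measurable response in this assay, which compound 1 and compound 2 could not show on their own. Compound 2 is known only through a limit, so the step is a bound and not a measured size: the limit of > 10000 nM in this assay, at which 1 of the 3 values shown sits.

The ring atoms, the sulfoxide and the placement of the fluorine all change together in this step, so their separate contributions remain unresolved. On these data alone, how a plain fluorophenyl group, a sulfone or the opposite sulfoxide stereoisomer would behave at this nitrogen also remains open.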